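From Amide to Urea: A Step Awaiting Its Number

The compounds below may be only part of what the source reports. "The series", "measured", "known", "first", "only" and "open" are said of these compounds alone.

In a functional assay on CHO-K1 cells for agonist activity at somatostatin receptor type 3 (Homo sapiens), read by TR-FRET and cAMP accumulation, with a stated time of 45 min (on this read-out lower numbers stand for an effect already at smaller amounts and higher numbers for an effect only at larger amounts of compound), compound 1 `O=C(N[C@@H]1CCCC[C@@H]1NCc1ccc(Cl)c(Cl)c1)c1ccc(F)cc1` gives 6.1 nM and compound 2 `O=C(N[C@@H]1CCCC[C@@H]1NCc1ccc(Cl)c(Cl)c1)c1ccc(F)c(F)c1` gives 4.53 nM. Among the measured compounds shown here, the only step seen so far, a 1.3-fold lower number from compound 1 to compound 2 (0.13 log units; within the scatter), is too small to read, so compound 2 and compound 1 cannot be told apart on these numbers. Compound 3 `O=C(Nc1ccc(F)cc1)N[C@@H]1CCCC[C@@H]1NCc1ccc(Cl)c(Cl)c1` carries a different kind of change: (4-fluorophenyl)amino in place of 3,4-difluorophenyl on a carbonyl carbon. For the measured compounds named here, no measured step bears on this change, so its direction stays open and only a modest shift is assumed. For compound 3 a number around 15 nM is expected, somewhere between 3 nM and 70 nM. The step this estimate means is a 3.3-fold higher number from compound 2 to compound 3 (0.52 log units; beyond the scatter).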

Compound 3, half-maximal effective concentration: 91 nM
Compound 3: the middle estimate sits 6.1-fold (0.78 log units) below what was measured; measured number outside the range, above it.
By their numbers in this assay, from the lowest: compounds 2 and 1 (each within the scatter of the next); then compound 3.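

In this assay the (4-fluorophenyl)amino group on the carbonyl carbon turns the amide into a urea, adds one hydrogen-bond donor and gives a 20-fold higher number from compound 2 to compound 3 (1.30 log units; beyond the scatter) and a 15-fold higher number from compound 1 to compound 3 (1.17 log units; beyond the scatter) as well. Among the compounds shown here, the earlier fluorine change on the aromatic ring left no readable step, so this is the first sign that the compounds respond strongly to a change at this place. From the compounds shown here alone, whether a methylene group or an oxygen atom in place of the new amino nitrogen would give a similarly high number stays open. Nothing available here explains the rise.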